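Acetoxy to Phenylcarbamate on a Shared Core

The source may hold more compounds than are shown below. What is called first, only, known or untested is meant among the compounds shown, and "the series" means these compounds.

Compound 1 `Cc1ccccc1C(=O)c1ccc2c(c1)C(n1ccccc1=O)=CC(C)(C)O2`: 6.83
Compound 2 `CC(=O)Oc1ccc2c(c1)C(n1ccccc1=O)=CC(C)(C)O2`: 5.6

In a functional assay (aorta) with Rattus norvegicus as the target (a lower number here means a less potent compound, a higher number a more potent compound, by a factor of ten per unit of this negative logarithm), compound 2 gives 5.6, the lowest of the two numbers; compound 1 gives 6.83. Within the data shown here, the one measured step, a number 1.23 log units lower from compound 1 to compound 2 (beyond the scatter), came with acetoxy in place of (2-methylphenyl)carbonyl on an aromatic carbon.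

Compound 3 `CC1(C)C=C(n2ccccc2=O)c2cc(OC(=O)Nc3ccccc3)ccc2O1` differs from compound 2 by anilino in place of methyl on a carbonyl carbon. Among the measured compounds shown here, no measured step touches this carbonyl carbon, so the single step bears only loosely: the compound carrying an aromatic ring in its side group gave the higher number. A moderate rise is therefore expected, a number 0.60 log units higher from compound 2 to compound 3 (beyond the scatter). Compound 3 is estimated at 6.2, within 5.4 to 7.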

Compound 3, logarithm of the reciprocal of the active concentration, log(1/C): 5.3
Estimate against measurement, compound 3: 0.90 log units above; the measured number lies below the stated range.
By their numbers in this assay, from the lowest: compounds 3 and 2 (each within the scatter of the next); then compound 1.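

In this assay, replacing methyl with anilino on this carbonyl carbon, which turns acetyl into phenylcarbamoyl, gives a number 0.30 log units lower from compound 2 to compound 3 (within the scatter). This position therefore accepts the larger group, with its six-membered aromatic ring and hydrogen-bond donor, without the number moving beyond the scatter. Nothing shown here explains why.

As far as these compounds go, it remains open whether a smaller amine such as dimethylamino, or a saturated ring such as cyclohexylamino, would give a similar number on this carbonyl carbon. From the compounds shown here alone, a chlorine or methoxy group on the anilino ring is equally open.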